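Swapping Trifluoromethyl for Chloro on the Benzyl Ring

The compounds below may be only part of what the source reports. "The series", "measured", "known", "first", "only" and "open" are said of these compounds alone.

Compound 1 `Cc1cccc(C)c1CC1CN/C(=N\N(C)C)CN(CC(=O)Nc2cccc(-c3cnn(C)c3)c2)C1=O` and compound 2 `CN(C)/N=C1/CN(CC(=O)Nc2cccc(-c3cnn(C)c3)c2)C(=O)C(Cc2c(F)cccc2C(F)(F)F)CN1` share the same core and differ only in the aryl group carried on the benzyl arm. In an assay on isolated protein for inhibition of kallikrein-7 (Mus musculus), read by fluorescence, with stated times of 10 min and 30 min (a higher number here means a weaker inhibitor, a lower number a stronger inhibitor), compound 1 gives 3800 nM. In the same assay compound 2 reaches only the limit of > 30000 nM, so its true value is not a number but lies somewhere past the end of the measured range. For the measured compounds named here, the single step between them, an at least 7.8-fold higher number from compound 1 to compound 2 (0.89 log units; beyond the scatter), therefore shows that the change from two methyl groups to fluoro plus trifluoromethyl costs potency, with the size of the loss known only as a lower bound because compound 2 sits at the limit of > 30000 nM in this assay, at which 1 of the 2 values shown sits.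

Compound 3 `CN(C)/N=C1/CN(CC(=O)Nc2cccc(-c3cnn(C)c3)c2)C(=O)C(Cc2c(F)cccc2Cl)CN1` keeps the fluoro group and makes one further change: chloro in place of trifluoromethyl on an aromatic carbon. Chloro is the smaller group, which brings compound 3 structurally closer to compound 1 than compound 2 is. Going by the values given here, since the only measured step runs from compound 1 to compound 2 and is a loss of at least modest size, the reverse-leaning change in compound 3 is expected to recover part of that loss, giving an estimated step of an at least 2.0-fold lower number from compound 2 to compound 3 (0.30 log units; that floor lies within the scatter). Compound 3 is therefore expected to show about 15000 nM in this assay, with a plausible range from 5000 nM to 60000 nM, and a real chance that it again reads only as a limit.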

Compound 3, half-maximal inhibitory concentration: 6000 nM
Compound 3: the middle estimate sits 2.5-fold (0.40 log units) above what was measured, within the range that was stated.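

In this assay, the step of an at least 5.0-fold lower number from compound 2 to compound 3 (0.69 log units; beyond the scatter) isolates the group on this aromatic carbon, ortho to a large group: with the fluoro group held in place, exchanging trifluoromethyl for chloro brings the reading back inside the measured range. On these data alone, this step gives only a floor, and its true size stays unknown, since compound 2 gives a limit rather than a number: the limit of > 30000 nM in this assay, at which 1 of the 3 values shown sits. The second new step, a 1.6-fold higher number from compound 1 to compound 3 (0.20 log units; within the scatter), lies within the scatter, so this assay does not separate the 2-chloro-6-fluorophenyl group from the 2,6-dimethylphenyl group, and the fluoro group alone does not carry the loss seen with compound 2.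

The compounds shown leave open how bromo or methoxy would read on this carbon, and whether trifluoromethyl would cost as much with methyl in place of the fluoro group. They also cannot tell what lies behind the step, or whether any group on this benzyl arm would bring a reading well under that of compound 1, which gives 3800 nM.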